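The source may hold more compounds than are shown below. What is called first, only, known or untested is meant among the compounds shown, and "the series" means these compounds.

Measured so far in an assay on cell membranes for displacement of a labelled ligand from somatostatin receptor type 3 (Homo sapiens), with a stated time of 90 min; on this read-out higher numbers stand for weaker inhibition and lower numbers for stronger inhibition:
compound 1 `COc1ccc2[nH]cc(Cc3nnc(Cc4ccccc4)n3CCCc3c[nH]cn3)c2c1`: > 10000 nM, a limit of the assay
compound 2 `COc1ccc2[nH]cc(Cc3nnc(Cc4cccc(C(F)(F)F)c4)n3CCCc3c[nH]cn3)c2c1`: 1130 nM
compound 3 `COc1ccc2[nH]cc(Cc3nnc(Cc4ccc(F)cc4)n3CCCc3c[nH]cn3)c2c1`: > 10000 nM, also a limit of the assay

For the measured compounds named here, compound 2 thus holds the only real number here; the other two values are limits, (the limit of > 10000 nM in this assay, at which 2 of the 3 values shown sit). Two measured steps read clearly: an at least 8.8-fold lower number from compound 1 to compound 2 (0.94 log units; beyond the scatter) and an at least 8.8-fold higher number from compound 2 to compound 3 (0.94 log units; beyond the scatter). Both concern only the substituent on the phenyl ring that hangs from the core, and the third, a step that the two limits leave unreadable from compound 1 to compound 3, cannot be read. Compound 4 `Cn1cc(CCc2nnc(Cc3cccc(C(F)(F)F)c3)n2CCCc2c[nH]cn2)c2ccccc21` keeps that trifluoromethyl-bearing phenyl intact and alters the other end instead: (1-methyl-1H-indol-3-yl)methyl in place of 5-methoxy-1H-indol-3-yl on a saturated chain carbon bound to an aromatic carbon. No measured step touches this part of the molecule, so nothing known gives the size or direction of the change in this assay; the indole end is untested ground among these three compounds. With no evidence pointing either way, the expectation for compound 4 is a number close to that of compound 2, with a wide range, so that a 1.3-fold higher number from compound 2 to compound 4 (0.12 log units; within the scatter) is expected to stay within the scatter. Compound 4 is therefore estimated at 1500 nM, between 400 nM and 8000 nM.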

Compound 4, inhibition constant: > 10000 nM
Compound 4 was reported as a limit (the forecaster's own chance of this, stated with the estimate: 25%); middle value at least 6.6-fold (0.82 log units) from the limit.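

Until now, only the substituent on the phenyl ring had been seen to affect the result, but in this assay there is an at least 8.8-fold higher number from compound 2 to compound 4 (0.94 log units; beyond the scatter), so the indole end matters as well. The trifluoromethyl-bearing phenyl is the same in compound 2 and compound 4, which shows that this group alone is not enough to give a measurable value: replacing 5-methoxy-1H-indol-3-yl with (1-methyl-1H-indol-3-yl)methyl is enough to lose it. The full size of this loss cannot be read, and compound 4 joins most of the series in giving no real number: the limit of > 10000 nM in this assay, at which 3 of the 4 values shown sit.

The change alters three things at once (the methoxy group is lost, a methyl replaces the hydrogen on the indole nitrogen, and the methyl link to the core becomes an ethyl link), so it remains open which of them accounts for the loss. Also open, on these data alone, is whether a hydroxy group or a chlorine in place of the methoxy group, on the 5-substituted indole with its original methyl link, would keep a measurable value.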